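This account rests on a few compounds, and the source may have more. Where it says the series, first, only, none or still open, it means among the compounds named here.

Compound 1 `Oc1ccccc1-c1cc(-c2cccs2)cc(-c2ccccc2O)n1`: > 50000 nM
Compound 2 `Oc1ccc(-c2cc(-c3cccs3)cc(-c3ccccc3O)n2)cc1`: > 50000 nM

In a functional assay on HCT-15 cells (Homo sapiens) for cytotoxicity, read by CCK-8 assay (a higher number here means a weaker inhibitor, a lower number a stronger inhibitor), compound 1 gives > 50000 nM, which is a limit and not a number. Compound 2 gives > 50000 nM, which is also only a limit. Both compounds therefore stand at the limit of > 50000 nM in this assay, at which 2 of the 2 values shown sit. Compound 3 `Oc1ccc(-c2cc(-c3ccoc3)cc(-c3ccccc3O)n2)cc1` has furan-3-yl in place of thiophen-2-yl on an aromatic carbon, opposite the ring nitrogen (furan-3-yl in place of thiophen-2-yl on an aromatic carbon). Among the measured compounds shown here, the only measured step, a step that the two limits leave unreadable from compound 1 to compound 2, has no readable size and involves a different group, so it offers no size or direction to carry over. A weak result in this assay is expected, given the value of compound 2 at > 50000 nM. The estimated change is an at least 1.2-fold lower number from compound 2 to compound 3 (0.09 log units; that floor lies within the scatter), and its direction is uncertain. For compound 3 the estimated value is 40000 nM, within an expected range of 12000 nM to 100000 nM.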

Compound 3, half-maximal inhibitory concentration: > 50000 nM
Compound 3 gave a limit, no number; the forecaster's own chance of this, stated with the estimate: 55%; middle value at least 1.2-fold (0.09 log units) from the limit.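

In this assay, among the compounds shown here, compound 2 and compound 3 each give a limit and not a number, so no step between them can be read. The compounds shown leave open whether any change to the shared core gives a readable value: the limit of > 50000 nM in this assay, at which 3 of the 3 values shown sit.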